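The source may hold more compounds than are shown below. What is called first, only, known or untested is meant among the compounds shown, and "the series" means these compounds.

Of the compounds shown here, three that share one core have been tested in a functional assay on MDA-MB-231 cells (Homo sapiens) for inhibition, read by sulforhodamine B assay, tested at 10 uM; on this read-out lower numbers stand for less inhibition and higher numbers for more inhibition at the one concentration tested (going by the name of the read-out). Compound 1 `CN1CCN(c2ccc(C3=NN(C(=O)CCCl)C(c4ccc(N(C)C)cc4)C3)cc2)CC1` gives 2.4%. Compound 2 `CN1CCN(c2ccc(C3=NN(C(=O)c4ccc(F)cc4)C(c4ccc(N(C)C)cc4)C3)cc2)CC1` gives 3.5%, and compound 3 `CN1CCN(c2ccc(C3=NN(S(=O)(=O)C4CC4)C(c4ccc(N(C)C)cc4)C3)cc2)CC1` gives 3.7%. Compound 1 sits at the bottom of these three numbers, yet the gaps to its neighbours, a number 1.1 percentage points higher from compound 1 to compound 2 (within the scatter) and a number 1.3 percentage points higher from compound 1 to compound 3 (within the scatter), both fall within the scatter, so the three cannot be told apart.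

Compound 4 `Cc1ccc(S(=O)(=O)N2N=C(c3ccc(N4CCN(C)CC4)cc3)CC2c2ccc(N(C)C)cc2)cc1` has not yet been measured in this assay. It differs from compound 1 in one place: (4-methylphenyl)sulfonyl in place of (2-chloroethyl)carbonyl on an amine nitrogen in a ring. Going by the values given here, two measured steps bear on this change. Replacing the same (2-chloroethyl)carbonyl by a sulfonyl group on the ring nitrogen gave a number 1.3 percentage points higher from compound 1 to compound 3 (within the scatter), and swapping an aromatic carbonyl for a sulfonyl group at the same place gave a number 0.2 percentage points higher from compound 2 to compound 3 (within the scatter). Neither step moved the read-out beyond the scatter, and all three compounds sit in the low region of the read-out at the concentration tested.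

Compound 4 is therefore expected to stay in the same low region, with a step of a number 1.6 percentage points higher from compound 1 to compound 4 (within the scatter) that lies within the scatter. The estimate for compound 4 is 4%, with a range from 0% to 14%.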

Compound 4, a percentage reported as inhibition, at one concentration (the size of the read-out at that concentration, not a potency): 10.7%
For compound 4 the middle estimate is 6.7 percentage points below the measured one; measured number inside the range.
By their numbers in this assay, from the lowest: compounds 1, 2, 3 and 4 (each within the scatter of the next).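

In this assay the (4-methylphenyl)sulfonyl group on the amine nitrogen in the ring gives a number 8.3 percentage points higher from compound 1 to compound 4 (within the scatter) and also a number 7.2 percentage points higher from compound 2 to compound 4 (within the scatter) when it replaces the aromatic carbonyl group. Keeping the sulfonyl in place and setting 4-methylphenyl in place of cyclopropyl on the sulfonyl sulfur gives a number 7 percentage points higher from compound 3 to compound 4 (within the scatter) and shows that an aromatic ring on the sulfonyl sulfur produces larger steps than any among the earlier compounds, yet none of these steps passes beyond the scatter, so compound 4 cannot be told apart from the other three. No separate measurement is available to explain these numbers.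

The compounds shown leave open whether any group at this position can produce a step beyond the scatter, for example a sulfonyl group carrying a longer carbon chain, or a carbonyl group carrying an amine or a carboxylic acid. They also leave open what the methyl group on the aromatic ring contributes, which an unsubstituted phenylsulfonyl group or one with a methoxy group in its place would help to settle.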